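Oxime and imine quinolinones: a benzyl replaces a butyl

The source may report more compounds than this note shows. Statements on the series, on what has been measured and on what is new or still open speak of the compounds shown alone.

Measured so far in a functional assay, read by spectrophotometry, with a stated time of 5 min; a lower number here means a stronger inhibitor, a higher number a weaker inhibitor:
compound 1 `O=c1[nH]c2ccccc2cc1/C=N/O` — 463000 nM
compound 2 `CCCC/N=C/c1cc2cc(C)ccc2[nH]c1=O` — 379000 nM
compound 3 `CCCC/N=C/c1cc2ccccc2[nH]c1=O` — 246000 nM

Compound 3 gives the lowest of the three numbers, but neither gap sets it apart: the step of a 1.5-fold lower number from compound 2 to compound 3 (0.19 log units; within the scatter) and the step of a 1.9-fold lower number from compound 1 to compound 3 (0.27 log units; within the scatter) both fall within the usual scatter, so no ordering among the three can be claimed.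

Compound 4 `O=c1[nH]c2ccccc2cc1/C=N/Cc1ccccc1` is obtained from compound 3 by one change: phenyl in place of propyl on a saturated chain carbon bound to a double-bonded nitrogen. Of the two measured steps, the one that bears most directly on this change is a 1.9-fold lower number from compound 1 to compound 3 (0.27 log units; within the scatter), since it also alters the group carried on the double-bonded nitrogen; it was small. The other step, a 1.5-fold lower number from compound 2 to compound 3 (0.19 log units; within the scatter), concerns a different part of the molecule and was also small. Among the compounds with values here, nothing measured so far shows the imine substituent moving the read-out beyond the scatter, and no phenyl has yet been tested in this position.

Compound 4 is therefore expected to land close to compound 3, with the step of a 1.2-fold lower number from compound 3 to compound 4 (0.09 log units; within the scatter) expected to stay within the scatter. The estimate for compound 4 in this assay is 200000 nM, with a range from 80000 nM to 500000 nM.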

Compound 4, half-maximal inhibitory concentration: 329000 nM
Beside the measured number, compound 4's estimate is 1.6-fold (0.22 log units) below it; the range from low to high includes it.
By their numbers in this assay, from the lowest: compounds 3, 4, 2 and 1 (each within the scatter of the next).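

In this assay, placing phenyl instead of propyl on the saturated chain carbon bound to the double-bonded nitrogen gives a 1.3-fold higher number from compound 3 to compound 4 (0.13 log units; within the scatter) and so stays within the scatter, even though the entering group has 6 heavy atoms and a six-membered aromatic ring, while the leaving group has 3 heavy atoms and no ring. The earlier compounds had tested only hydroxy and butyl on the double-bonded nitrogen, so this result extends the finding to a substituent that carries an aromatic ring: in the compounds shown, no change at this position moves the read-out beyond the scatter. No measurement is available that bears on the reason for this result.

The compounds shown leave open whether an amine or a carboxylic acid on that chain carbon, or a much longer chain on the double-bonded nitrogen, would shift the number beyond the scatter. They also leave open whether chlorine or methoxy on the phenyl ring of compound 4, or on the aromatic carbon where compound 2 carries its methyl, would do so.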